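Moving an ester from one position to another

The source may report more compounds than this note shows. Statements on the series, on what has been measured and on what is new or still open speak of the compounds shown alone.

This study follows how long a set of amino-acid ester prodrugs survive. The read-out is an ADME assay on a cell-free system (plasma, Rattus norvegicus) for metabolic stability, read by LC-MS, with a stated time of 120 min, tested at 200 uM; on this read-out lower numbers stand for a shorter-lived compound and higher numbers for a longer-lived compound. Compound 3 `N[C@@H](CCC(=O)OC[C@H]1O[C@@H](n2cc(F)c(=O)[nH]c2=O)C[C@@H]1O)C(=O)O` gives 1.91 h. Compound 1 `N[C@@H](CC(=O)OC[C@H]1O[C@@H](n2cc(F)c(=O)[nH]c2=O)C[C@@H]1O)C(=O)O` carries the shared core of compound 3 with a shorter amino acid: amino(carboxy)methyl in place of 2-amino-2-carboxyethyl on a saturated chain carbon bound to a carbonyl carbon. In this assay compound 1 gives 2.5 h, and the step of a 1.3-fold higher number from compound 3 to compound 1 (0.12 log units; within the scatter) is small. Compound 2 `N[C@@H](CCC(=O)O[C@H]1C[C@H](n2cc(F)c(=O)[nH]c2=O)O[C@@H]1CO)C(=O)O` has the same atoms as compound 3 joined differently, with the ester on the other hydroxyl; the difference between the two cores is not broken down here. In this assay compound 2 gives 1.62 h, a number close to those of compound 1 and compound 3. Compound 4 `N[C@@H](CC(=O)O[C@H]1C[C@H](n2cc(F)c(=O)[nH]c2=O)O[C@@H]1CO)C(=O)O` is not yet measured. It is related to compound 2 by the same kind of change as compound 1 is to compound 3, in the same place: amino(carboxy)methyl in place of 2-amino-2-carboxyethyl on a saturated chain carbon bound to a carbonyl carbon. Because the measured step of a 1.3-fold higher number from compound 3 to compound 1 (0.12 log units; within the scatter) stayed within the usual scatter, the step from compound 2 to compound 4 is expected to be similar, about a 1.2-fold higher number from compound 2 to compound 4 (0.09 log units; within the scatter). Compound 4 is therefore estimated to give a half-life of roughly 2 h, expected between 1.2 h and 3.3 h.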

Compound 4, half-life: 2.06 h
The estimate for compound 4 lay 1.0-fold (0.01 log units) below the measured number; the measured number falls inside the stated range.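

In this assay, putting amino(carboxy)methyl in place of 2-amino-2-carboxyethyl gives a 1.3-fold higher number from compound 2 to compound 4 (0.10 log units; within the scatter), and the change reads the same on both cores: the same change on two cores in this assay, a 1.3-fold higher number (0.12 log units; within the scatter) from compound 3 to compound 1 and a 1.3-fold higher number (0.10 log units; within the scatter) from compound 2 to compound 4, 1.0-fold (0.01 log units) apart, within the scatter of two such steps. So in these four compounds, moving the ester to the other hydroxyl leaves the outcome of this change as it was, and what carries over from one core to the other is a step too small to tell from repeat-measurement noise. This does not show that the shorter chain truly gives a longer-lived compound, and two cores cannot establish that the same would hold on a third.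

The compounds shown leave open whether a chain longer than 3-amino-3-carboxypropyl, or an amide in place of the ester, would move the half-life by more than the scatter. They also leave open what happens to the half-life when both hydroxyls carry an ester.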